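Expected Potency of a Trifluoromethylphenyl Replacement

The source may hold more compounds than are shown below. What is called first, only, known or untested is meant among the compounds shown, and "the series" means these compounds.

In an assay on cells for agonist activity at Bile acid receptor (Homo sapiens), read by HTRF, with a stated time of 1 h (on this read-out higher numbers stand for an effect only at larger amounts of compound and lower numbers for an effect already at smaller amounts), compound 2, `O=C(O)c1ccc2nc(N3CCC(OCc4c(-c5c(F)cccc5F)noc4C4CC4)CC3)sc2c1`, gives 31 nM. Among the compounds with values here, of the two values measured so far this is the higher one, and the only other measured compound is its nearest neighbour: compound 1, `O=C(O)c1ccc2nc(N3CCC(OCc4c(-c5c(Cl)cccc5Cl)noc4C4CC4)CC3)sc2c1`, which in this assay gives 8.3 nM. Within the data shown here, the single step between them, a 3.7-fold higher number from compound 1 to compound 2 (0.57 log units; beyond the scatter), is the only measured change on this part of the molecule.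

Compound 3, `O=C(O)c1ccc2nc(N3CCC(OCc4c(-c5ccccc5C(F)(F)F)noc4C4CC4)CC3)sc2c1`, is related to compound 2 by one change: 2-(trifluoromethyl)phenyl in place of 2,6-difluorophenyl on an aromatic carbon. Among the measured compounds shown here, the one step that bears on it, a 3.7-fold higher number from compound 1 to compound 2 (0.57 log units; beyond the scatter), shows that exchanging the two halogens on this phenyl moved the number beyond the scatter, so substitution on this ring clearly matters. For the measured compounds named here, no measured pair covers a trifluoromethyl group, so the direction for compound 3 rests on that single comparison alone. Since the fluorinated analogue gave the higher number of the two, a return toward the lower values seems more likely than a further rise, but with wide uncertainty.

Compound 3 is therefore expected to give 15 nM in this assay, with a range from 4 nM to 60 nM, which corresponds to an expected step of a 2.1-fold lower number from compound 2 to compound 3 (0.32 log units; beyond the scatter).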

Compound 3, half-maximal effective concentration in the Bile acid receptor assay: 66 nM
The estimate for compound 3 lay 4.4-fold (0.64 log units) below the measured number; the measured number lies above the stated range.
By their numbers in the Bile acid receptor assay, from the lowest: compound 1; then compound 2; then compound 3.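

In the Bile acid receptor assay, the 2-(trifluoromethyl)phenyl group on the aromatic carbon next to the ring nitrogen gives compound 3 66 nM as the highest number of the three compounds, with a 2.1-fold higher number from compound 2 to compound 3 (0.33 log units; beyond the scatter) and an 8.0-fold higher number from compound 1 to compound 3 (0.90 log units; beyond the scatter). The earlier pair showed only that exchanging the two halogens on this phenyl shifts the number; this result shows that a change in the kind and pattern of substitution on the ring also shifts it, and that a move away from 2,6-difluorophenyl does not by itself bring the number down. In a physicochemical assay for solubility, in simulated intestinal fluid, at pH 6.8 (on this read-out higher numbers stand for higher solubility and lower numbers for lower solubility), compound 2 gives 169000 nM and compound 3 gives 131000 nM in the same exchange, with a 1.3-fold lower number from compound 2 to compound 3 (0.11 log units; within the scatter), within the scatter, so the two compounds are separated at the receptor but not in solubility, and no measured information here explains the shift at the receptor.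

The compounds shown do not separate the contribution of the trifluoromethyl group from that of having a single substituent on the phenyl rather than two. From the compounds shown here alone, a plain phenyl, a 2-chlorophenyl or a 2-methoxyphenyl at this position would each bear on that question, and how any of them would behave remains open.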